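The compounds below may be only part of what the source reports. "The series", "measured", "known", "first", "only" and "open" are said of these compounds alone.

Going by the values given here, compound 2 `COc1cc(Cl)cc(-c2nn(-c3cccc(NC(=O)Nc4cccc(C(F)(F)F)c4)c3)cc2-c2ccncc2)c1` is one of two compounds measured in a functional assay on COLO 205 cells (Homo sapiens) for inhibition, read by sulforhodamine B assay, with a stated time of 48 h, tested at 100 uM; on this read-out lower numbers stand for a stronger effect and higher numbers for a weaker effect at the one concentration tested. In this assay compound 2 gives -95%, the lowest of the two numbers, which on this read-out means the stronger effect. Its nearest neighbour is compound 1 `COc1cc(Cl)cc(-c2nn(-c3cccc(NC(=O)Nc4ccc(Cl)c(C(F)(F)F)c4)c3)cc2-c2ccncc2)c1`, which differs from it in one place, a chloro on an aromatic carbon; in this assay compound 1 gives -79%, and the step of a number 16 percentage points lower from compound 1 to compound 2 (beyond the scatter) lies beyond the scatter.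

Compound 3 `COc1cc(Cl)cc(-c2nn(-c3cccc(NC(=O)c4cccc(C(F)(F)F)c4)c3)cc2-c2ccncc2)c1` has not yet been measured. It differs from compound 2 in one place: 3-(trifluoromethyl)phenyl in place of (3-(trifluoromethyl)phenyl)amino on a carbonyl carbon. This replaces a urea-type linkage with an amide, since the amino part of the (3-(trifluoromethyl)phenyl)amino group is removed. Among the compounds with values here, no measured step of this kind exists among the two compounds; the only step available, a number 16 percentage points lower from compound 1 to compound 2 (beyond the scatter), concerns a chloro and says nothing direct about this change, so the expectation rests on little.

The estimated step of a number 25 percentage points higher from compound 2 to compound 3 (beyond the scatter) is expected to point toward a weaker effect, with a wide range. Compound 3 is expected to give an estimated -70% in this assay, within a range from -100% to -30%.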

Compound 3, a percentage reported as activity, at one concentration (the size of the read-out at that concentration, not a potency): 45%
Compound 3: the middle estimate sits 115 percentage points below what was measured; the measured number lies above the stated range.
By their numbers in this assay, from the lowest: compound 2; then compound 1; then compound 3.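

Shortening the link on the carbonyl carbon changes far more than the chloro on the outer aromatic ring did. Replacing (3-(trifluoromethyl)phenyl)amino with 3-(trifluoromethyl)phenyl, which turns the urea-type linkage into an amide, gives in this assay a large step, a number 140 percentage points higher from compound 2 to compound 3 (beyond the scatter), compared with the modest a number 16 percentage points lower from compound 1 to compound 2 (beyond the scatter), and the step of a number 124 percentage points higher from compound 1 to compound 3 (beyond the scatter), in which the chloro also goes, is large as well. So the amino part at this position weighs much more in this read-out than the chloro does, and compound 3 alone among the three gives a number above zero, while compound 1 and compound 2 give numbers below it; nothing measured here explains this large difference.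

Going by these compounds alone, with only this one change at the carbonyl carbon, it stays open whether the effect follows the amino nitrogen itself or the length of the link, which a methylene group or an oxygen atom in its place could help separate. As far as these compounds go, it also stays open whether a methylamino group would keep the effect, and whether 4-chloro-3-(trifluoromethyl)phenyl on the amide would shift the number of compound 3.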